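This account rests on a few compounds, and the source may have more. Where it says the series, first, only, none or still open, it means among the compounds named here.

Working notes on the nitro-substituted series. Compound 1, `COc1cc(/C=C2\Cc3ccccc3/C(=C\c3ccc([N+](=O)[O-])cc3)C2=O)ccc1O`, gives 3800 nM in a functional assay on HSC-3 cells (Homo sapiens) for cytotoxicity; on this read-out higher numbers stand for lower toxicity in this test and lower numbers for higher toxicity in this test. Compound 2, `COc1ccc(/C=C2\Cc3ccccc3/C(=C\c3ccc([N+](=O)[O-])cc3)C2=O)cc1OC`, gives 4200 nM in this assay. The change from compound 1 to compound 2 is methyl in place of hydrogen on an oxygen on an aromatic ring, and the step was a 1.1-fold higher number from compound 1 to compound 2 (0.04 log units; within the scatter). Compound 3, `O=C1/C(=C/c2ccc(O)cc2)CCC/C1=C\c1ccc([N+](=O)[O-])cc1`, gives 13000 nM in this assay, the highest number of the three; the difference between the core of compound 3 and the core of compound 1 is not broken down here. Compound 4, `COc1ccc(/C=C2\CCC/C(=C\c3ccc([N+](=O)[O-])cc3)C2=O)cc1`, is not yet measured. It differs from compound 3 by methyl in place of hydrogen on an oxygen on an aromatic ring, the same change as that from compound 1 to compound 2, at the same place. On that precedent, the expected step is a 1.1-fold higher number from compound 3 to compound 4 (0.03 log units; within the scatter), resting on the near-flat step a 1.1-fold higher number from compound 1 to compound 2 (0.04 log units; within the scatter). For compound 4 the estimate is 14000 nM, with a likely range of 7000 nM to 28000 nM.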

Compound 4, half-maximal cytotoxic concentration: > 400000 nM
Compound 4: a limit, no number; the forecaster's own chance of this, stated with the estimate: 10%; at least 28-fold (1.45 log units) between middle value and limit.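

Hydroxy to methoxy here gives an at least 30-fold higher number from compound 3 to compound 4 (1.48 log units; beyond the scatter), and the change does not carry over between the two cores in this assay: the same change on two cores in this assay, a 1.1-fold higher number (0.04 log units; within the scatter) from compound 1 to compound 2 and an at least 30-fold higher number (1.48 log units; beyond the scatter) from compound 3 to compound 4, at least 27-fold (1.44 log units) apart, beyond the scatter of two such steps

Compound 4 gives > 400000 nM, which is a limit of the assay and not a number: the limit of > 400000 nM in this assay, at which 1 of the 4 values shown sits.

This shows that the outcome of the change depends on the core in these two pairs, but it does not show the true size of the step or which part of the cores accounts for the gap, and one pair per core supports no general rule.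

Open, as far as these compounds go, is how an ethoxy group, a longer chain on that oxygen, would read on each core. Also open, from the compounds shown here alone, is how an amine in place of the hydroxy would read there.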